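Removing one methoxy from the chalcone aryl of compound 2

A few compounds are considered here, and "the series" means these few. Any claim that something is new, unique, unknown or untested is made for them only; others in the source may bear on it.

Measured so far:
compound 1, `COc1cc(-c2cc(/C=C/C(=O)c3ccc(N)cc3)[nH]n2)cc(OC)c1OC`: > 100000 nM
compound 2, `COc1ccc(C(=O)/C=C/c2cc(-c3cc(OC)c(OC)c(OC)c3)n[nH]2)cc1OC`: 6400 nM

Compound 1 has only a limit in a functional assay on HCT-15 cells (Homo sapiens) for inhibition, read by sulforhodamine B assay, with a stated time of 48 h (a lower number here means that less compound is tolerated, a higher number that more compound is tolerated), and gives > 100000 nM there. Among the compounds with values here, compound 2, in contrast, gives a real number, 6400 nM, and it is the only number in this assay. Within the data shown here, the one measured step, an at least 15-fold lower number from compound 1 to compound 2 (1.19 log units; beyond the scatter), is large, and its size rests on the fact that compound 1 sits at a limit (the limit of > 100000 nM in this assay, at which 1 of the 2 values shown sits).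

Compound 3, `COc1ccc(C(=O)/C=C/c2cc(-c3cc(OC)c(OC)c(OC)c3)n[nH]2)cc1`, differs from compound 2 by hydrogen in place of methoxy on an aromatic carbon; cut one bond further out, this reads 3,4-dimethoxyphenyl to 4-methoxyphenyl. The measured step exchanged a whole aryl group on the carbonyl carbon and bears on this change only loosely: it shows that the identity of the aryl on the carbonyl carbon matters, not how much a single methoxy contributes. Without a closer precedent, the step from compound 2 to compound 3 is expected to be modest, possibly within the scatter, as a 1.4-fold higher number from compound 2 to compound 3 (0.15 log units; within the scatter). Compound 3 is therefore estimated at 9000 nM, within 2500 nM to 35000 nM.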

Compound 3, concentration lethal to 50% of the cells: > 100000 nM
Compound 3: a limit, no number (the forecaster's own chance of this, stated with the estimate: 15%); middle value at least 11-fold (1.04 log units) away from the limit.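

The 3,4-dimethoxyphenyl group now proves to depend on a single methoxy: in this assay, hydrogen in place of methoxy on an aromatic carbon, ortho to a methoxy group, gives an at least 15-fold higher number from compound 2 to compound 3 (1.19 log units; beyond the scatter). Within the data shown here, the earlier step exchanged a whole aryl group, whereas this one shows that the change from 3,4-dimethoxyphenyl to 4-methoxyphenyl alone is enough to separate the one compound with a number from a compound at the limit. Compound 3 gives > 100000 nM, which is a limit and not a number, so the step from compound 2 has a readable lower size only, and the step between compound 1 and compound 3 cannot be read: the limit of > 100000 nM in this assay, at which 2 of the 3 values shown sit.

The compounds shown leave open whether this place needs a methoxy as such, or whether a hydroxyl, an ethoxy or a fluorine on the same aromatic carbon would also give a number in this assay. They also leave open how 4-aminophenyl and 4-methoxyphenyl compare, and whether the methoxy that stays in compound 3 matters at all, a question that a 3-methoxyphenyl group would address.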